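This account rests on a few compounds, and the source may have more. Where it says the series, first, only, none or still open, it means among the compounds named here.

In a functional assay on CHO cells for antagonist activity at prostaglandin E2 receptor EP3 subtype (Homo sapiens), read by FLIPR, with a stated time of 1 h (a lower number here means a stronger inhibitor, a higher number a weaker inhibitor), compound 3 `CC(C)C1(c2cc(Cl)c(-c3ccc4ccccc4c3)[nH]c2=O)OC(=O)NC1=O` gives 50.1 nM, the lowest of the three numbers recorded so far. Compound 1 `O=C1NC(=O)C(c2ccc(-c3ccc4ccccc4c3)[nH]c2=O)(C2CCOCC2)O1` gives 200 nM, a gap beyond the usual scatter, and compound 2 `COc1cc(-c2ccc3ccccc3c2)ccc1C1(C)OC(=O)NC1=O` gives 3160 nM, further away still. Compound 4 `Cc1cc(C2(C(C)C)OC(=O)NC2=O)c(=O)[nH]c1-c1ccc2ccccc2c1` has not yet been measured in this assay. It differs from compound 3 in a single place: methyl in place of chloro on an aromatic carbon. For the measured compounds named here, no measured pair in this set shows what such a swap does, so the size of the step rests on expectation alone. A group of like size enters where one leaves, and no step beyond the scatter is expected in either direction. Compound 4 is therefore expected to give about 63 nM, within a range of 20 nM to 200 nM. The expected step from compound 3 to compound 4 is a 1.3-fold higher number from compound 3 to compound 4 (0.10 log units; within the scatter).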

Compound 4, inhibition constant: 6.31 nM
Compound 4: middle estimate off by 10-fold (1.00 log units), on the high side, and the stated range ends above it.
By their numbers in this assay, from the lowest: compound 4; then compound 3; then compound 1; then compound 2.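

In this assay, methyl in place of chloro gives a 7.9-fold lower number from compound 3 to compound 4 (0.90 log units; beyond the scatter), so this aromatic carbon, ortho to a large group and two atoms from the ring nitrogen, responds clearly to the exchange of one heavy atom for another. For the compounds shown here, it is the first single-place step available in this set, and it shows that these two groups are not interchangeable here. No measurement at hand accounts for the step.

Going by these compounds, whether ethyl, bromo or methoxy at this position would give a number lower or higher than methyl remains open. So does whether the step would persist if the other groups on the core were changed.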